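A few compounds are considered here, and "the series" means these few. Any claim that something is new, unique, unknown or untested is made for them only; others in the source may bear on it.

Measured so far:
compound 1, `O=C(O)c1ccc(Cn2c(C(=O)O)cc3cc(S(=O)(=O)N(Cc4ccccc4)Cc4ccccc4)ccc32)cc1`, 100%;
compound 2, `O=C(O)c1cn(Cc2ccccc2)c2ccc([N+](=O)[O-])cc12`, 65%;
compound 3, `O=C(O)c1ccc(Cn2cc(C(=O)O)c3cc([N+](=O)[O-])ccc32)cc1`, 54%.

All three were tested in an assay on cells (Oocyte) for inhibition of pannexin-1 (Mus musculus), read by voltage clamp, tested at 50 uM, in the presence of a further agent that is not named here (a higher number here means more inhibition at the concentration tested (going by the name of the read-out), a lower number less inhibition), where compound 1 gives the highest of the three readings. Compound 4, `O=C(O)c1cc2cc(S(=O)(=O)N(Cc3ccccc3)Cc3ccccc3)ccc2n1Cc1ccccc1`, has not been measured in this assay yet. It is made from compound 1 by one change: hydrogen in place of carboxy on an aromatic carbon. The same change has already been measured once, from compound 3 to compound 2: hydrogen in place of carboxy on an aromatic carbon. There it gave a number 11 percentage points higher from compound 3 to compound 2 (beyond the scatter), an upward step. The two starting points, compound 1 and compound 3, carry different cores; the difference between the two cores is not broken down here. Because compound 1 already gives 100%, the top of what this read-out can show, the expected step from compound 1 to compound 4 in this assay is estimated at a number 5 percentage points lower from compound 1 to compound 4 (within the scatter), smaller than the earlier upward step and within the scatter. On that basis compound 4 is expected to give about 95% in this assay, most likely between 80% and 100%.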

Compound 4, a percentage reported as inhibition, at one concentration (the size of the read-out at that concentration, not a potency): 41%
The estimate for compound 4 lay 54 percentage points above the measured number, outside the stated range (below it).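

In this assay, trading the 4-carboxybenzyl group for benzyl gives a number 59 percentage points lower from compound 1 to compound 4 (beyond the scatter), and this does not match what the same change did on the other core: the same change on two cores in this assay, a number 11 percentage points higher (beyond the scatter) from compound 3 to compound 2 and a number 59 percentage points lower (beyond the scatter) from compound 1 to compound 4, 70 percentage points apart, beyond the scatter of two such steps

A step measured on the core of compound 3 is therefore no safe guide to the same change on the core of compound 1, where keeping the carboxy goes with much the higher reading. For the compounds shown here, what this does not show is which feature of the two cores makes the difference: they differ in several places at once, only two pairs are available, and nothing here explains the mechanism behind the gap.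

Going by these compounds alone, open is which part of the core sets the size and direction of the step, as no compound here separates those differences one at a time. Also open, from the compounds shown here alone, is whether a methyl ester, a primary amide or an amine in place of the carboxy on the benzyl ring would keep the reading of compound 1 or lose it as compound 4 does.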